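The compounds below may be only part of what the source reports. "The series", "measured", "known", "first", "only" and "open" are said of these compounds alone.

In a functional assay on MCF7 cells (Homo sapiens) for antiproliferative activity, read by MTT assay, with a stated time of 48 h; on this read-out higher numbers stand for weaker inhibition and lower numbers for stronger inhibition:
- compound 1 `Cc1nc2ccccc2nc1Oc1ccc(C(=O)N[C@@H](C)C(=O)O)cc1`: 25600 nM
- compound 2 `COC(=O)CNC(=O)c1ccc(Oc2nc3ccccc3nc2NC(C)(C)C)cc1`: > 50000 nM (a limit)
- compound 3 `COC(=O)[C@H](CC(C)C)NC(=O)c1ccc(Oc2nc3ccccc3nc2NC(C)(C)C)cc1`: > 50000 nM (a limit)

Compound 3 gives only a limit, > 50000 nM, so no number anchors this step. Compound 4 `C[C@H](NC(=O)c1ccc(Oc2nc3ccccc3nc2NC(C)(C)C)cc1)C(=O)O` has 1-carboxyethyl in place of 1-(methoxycarbonyl)-3-methylbutyl on an amide-type nitrogen. Within the data shown here, the one measured step, a step that the two limits leave unreadable from compound 2 to compound 3, gives no size to carry over. The series otherwise shows (the limit of > 50000 nM in this assay, at which 2 of the 3 values shown sit). Among the measured compounds shown here, compound 1, which also carries 1-carboxyethyl on an amide-type nitrogen, gives 25600 nM, the only numeric guide here. On that basis, a small move toward stronger inhibition is expected: an at least 1.6-fold lower number from compound 3 to compound 4 (0.22 log units; that floor lies within the scatter). A result at the limit remains quite possible. The estimate for compound 4 is 30000 nM, with an expected range of 12000 nM to 50000 nM.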

Compound 4, half-maximal inhibitory concentration: 29400 nM
Beside the measured number, compound 4's estimate is 1.0-fold (0.01 log units) above it; measured number inside the range.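

Compound 4 gives the (tert-butyl)amino series a number in this assay, and 1-carboxyethyl on the amide-type nitrogen accounts for the steps: an at least 1.7-fold lower number from compound 3 to compound 4 (0.23 log units; that floor lies within the scatter) and an at least 1.7-fold lower number from compound 2 to compound 4 (0.23 log units; that floor lies within the scatter). Compound 2 and compound 3 remain limits of the assay: the limit of > 50000 nM in this assay, at which 2 of the 4 values shown sit. With 1-carboxyethyl in place, the aromatic-carbon swap gives a 1.1-fold higher number from compound 1 to compound 4 (0.06 log units; within the scatter).

On these data alone, the ester-to-acid change and the chain change occur together in these steps, so their separate contributions remain open. A methyl ester of 1-carboxyethyl and a 1-carboxy-3-methylbutyl group on the same nitrogen would separate them.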